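The source may hold more compounds than are shown below. What is called first, only, known or untested is meant among the compounds shown, and "the series" means these compounds.

Working notes on the phenylthiazole series.

Compound 1 `c1ccc(-c2nc(CNc3nccc(NC4CC4)n3)cs2)cc1` is the reference point. Among the compounds with values here, in a toxicity assay on U-251 cells (Homo sapiens) for inhibition, read by MTT assay, with a stated time of 72 h (a lower number here means a stronger inhibitor, a higher number a weaker inhibitor), compound 1 gives 59500 nM, the highest of the three numbers measured so far. Compound 2 `c1ccc(-c2nc(CNc3nccc(NC4CCCCC4)n3)cs2)cc1` gives 10800 nM, and compound 3 `c1ccc(-c2nc(CNc3nccc(N4CCC4)n3)cs2)cc1` gives 29300 nM. The step of a 5.5-fold lower number from compound 1 to compound 2 (0.74 log units; beyond the scatter) shows that a larger ring on the nitrogen on the aromatic ring brings the number down. The step of a 2.0-fold lower number from compound 1 to compound 3 (0.31 log units; beyond the scatter) shows that azetidin-1-yl, which carries no hydrogen-bond donor, also lowers the number, though by less; the step of a 2.7-fold higher number from compound 2 to compound 3 (0.43 log units; beyond the scatter) separates these two cases.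

Compound 4 `CCCN(CCC)c1ccnc(NCc2csc(-c3ccccc3)n2)n1` is not yet measured. It differs from compound 1 as follows: dipropylamino in place of cyclopropylamino on an aromatic carbon. The change removes the hydrogen-bond donor, as in compound 3, and adds more carbon than the change to compound 2 did, so both measured steps bear on it. Because a 5.5-fold lower number from compound 1 to compound 2 (0.74 log units; beyond the scatter) and a 2.0-fold lower number from compound 1 to compound 3 (0.31 log units; beyond the scatter) both point the same way, a modest lowering of the number is expected; the step of a 3.3-fold lower number from compound 1 to compound 4 (0.52 log units; beyond the scatter) is the estimated size. Compound 4 is therefore expected to give about 18000 nM in this assay, within a range from 6000 nM to 50000 nM.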

Compound 4, half-maximal inhibitory concentration: 16200 nM
Compound 4: the middle estimate sits 1.1-fold (0.05 log units) above what was measured; the measured number falls inside the stated range.
By their numbers in this assay, from the lowest: compounds 2, 4 and 3 (each within the scatter of the next, the first and the last beyond it); then compound 1.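

Working notes, continued. In this assay, the step of a 3.7-fold lower number from compound 1 to compound 4 (0.57 log units; beyond the scatter) shows that a ring on the nitrogen is not required at this position: dipropylamino has no ring and no hydrogen-bond donor, yet it still moves the number away from that of compound 1. The steps of a 1.8-fold lower number from compound 3 to compound 4 (0.26 log units; within the scatter) and a 1.5-fold higher number from compound 2 to compound 4 (0.18 log units; within the scatter) both lie within the scatter, so this open-chain group cannot be told apart from azetidin-1-yl or cyclohexylamino, even though the step of a 2.7-fold higher number from compound 2 to compound 3 (0.43 log units; beyond the scatter) keeps those two ring-bearing compounds apart. No measurement offered here bears on the cause of these steps.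

Compound 4 loses the hydrogen-bond donor and gains carbon in a single change, so the compounds shown do not separate these two contributions; propylamino, which keeps the donor on an open chain, and dibutylamino, a longer chain without the donor, would bear directly on that question. From the compounds shown here alone, it also remains open whether a ring carrying a second heteroatom, such as morpholin-4-yl, or an amine-bearing side chain at this position would stay with compounds 2, 3 and 4 or fall nearer compound 1.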